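The source may report more compounds than this note shows. Statements on the series, on what has been measured and on what is new or still open speak of the compounds shown alone.

Within the data shown here, in a functional assay on HepG2 cells (Homo sapiens) for antiproliferative activity, read by MTT assay, with a stated time of 72 h (a higher number here means a weaker inhibitor, a lower number a stronger inhibitor), compound 1 `COc1cc2c(Nc3ccc(C#N)cc3)ncnc2cc1OCCCN1CCCC1` gives 20900 nM, the only exact number so far. Compound 2 `COc1cc2c(Nc3ccc(C#N)cc3)ncnc2cc1OCCCN1CCc2ccccc2C1` reaches only a limit of the assay, > 100000 nM. Among the measured compounds shown here, the one measured step, an at least 4.7-fold higher number from compound 1 to compound 2 (0.67 log units; beyond the scatter), alters the far end of the saturated chain, so it says little about the cyanophenyl group. Compound 3 `COc1cc2c(Nc3ccccc3C#N)ncnc2cc1OCCCN1CCCC1` keeps the chain of compound 1 but carries 2-cyanophenyl in place of 4-cyanophenyl on a nitrogen on an aromatic ring. For the measured compounds named here, no measured step covers this change, so only a small rise within this assay is expected, an estimated 1.2-fold higher number from compound 1 to compound 3 (0.08 log units; within the scatter). The expected value for compound 3 is 25000 nM, within an estimated range of 8000 nM to 80000 nM.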

Compound 3, half-maximal inhibitory concentration: 24500 nM
Compound 3: middle estimate off by 1.0-fold (0.01 log units), on the high side; the measured number falls inside the stated range.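

In this assay, 2-cyanophenyl in place of 4-cyanophenyl on a nitrogen on an aromatic ring gives a 1.2-fold higher number from compound 1 to compound 3 (0.07 log units; within the scatter), so these two groups cannot be told apart here. Among these compounds, the only earlier step changed the far end of the chain, so this is the first reading of a change on this nitrogen. Nothing measured here bears on why the two groups read alike. Still open, on these data alone, is whether 3-cyanophenyl or plain phenyl, with no nitrile, would give a different number on this nitrogen. Also open, as far as these compounds go, is how 2-cyanophenyl behaves with the 1,2,3,4-tetrahydroisoquinolin-2-yl chain end of compound 2.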